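Swapping Chlorophenyl for Thiazolyl: Will Toxicity Return?

The compounds below may be only part of what the source reports. "The series", "measured", "known", "first", "only" and "open" are said of these compounds alone.

Three compounds share one core and differ only in the aromatic group attached on an aromatic carbon of a six-membered aromatic ring with one nitrogen, next to the ring nitrogen. Compound 1 `COc1nc(-c2ccncc2)ccc1[C@@H](c1ccccc1)[C@@](O)(CCN(C)C)c1cccc2ccccc12` carries pyridin-4-yl there; in a toxicity assay on HeLa cells (Homo sapiens) for cytotoxicity (on this read-out lower numbers stand for higher toxicity in this test and higher numbers for lower toxicity in this test), compound 1 gives 9.6 ug/mL. Compound 2 `COc1nc(-c2ccc(C(F)(F)F)cc2)ccc1[C@@H](c1ccccc1)[C@@](O)(CCN(C)C)c1cccc2ccccc12` carries 4-(trifluoromethyl)phenyl; in this assay compound 2 reaches only a limit of the test, > 64 ug/mL, not a number. Compound 3 `COc1nc(-c2ccccc2Cl)ccc1[C@@H](c1ccccc1)[C@@](O)(CCN(C)C)c1cccc2ccccc12` carries 2-chlorophenyl; in this assay compound 3 likewise stops at the limit > 64 ug/mL. Compound 3 thus stands at the limit of > 64 ug/mL in this assay, at which 2 of the 3 values shown sit.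

Going by these compounds, the measured steps are an at least 6.6-fold higher number from compound 1 to compound 2 (0.82 log units; beyond the scatter) and an at least 6.6-fold higher number from compound 1 to compound 3 (0.82 log units; beyond the scatter), while a step that the two limits leave unreadable from compound 2 to compound 3 remains open.

Compound 4 `COc1nc(-c2cnsc2)ccc1[C@@H](c1ccccc1)[C@@](O)(CCN(C)C)c1cccc2ccccc12` makes the change (1,2-thiazol-4-yl in place of 2-chlorophenyl on an aromatic carbon). The incoming ring resembles pyridin-4-yl in being a small aromatic ring with ring hetero atoms and hydrogen-bond acceptors, and compound 1 with pyridin-4-yl gives 9.6 ug/mL, so the number for compound 4 is expected to fall back somewhat toward that value. Compound 4 is therefore expected to give about 30 ug/mL, with a range from 10 ug/mL to 70 ug/mL. The expected step is an at least 2.1-fold lower number from compound 3 to compound 4 (0.32 log units; beyond the scatter), though its true size cannot be read against a limit.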

Compound 4, half-maximal cytotoxic concentration: 28.8 ug/mL
Estimate against measurement, compound 4: 1.0-fold (0.02 log units) above; measured number inside the range.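

In this assay, this position now gives a second readable number, and the change from a carbon-only ring to 1,2-thiazol-4-yl brings an at least 2.2-fold lower number from compound 3 to compound 4 (0.34 log units; beyond the scatter). The same ring set against the other carbon-only group gives an at least 2.2-fold lower number from compound 2 to compound 4 (0.34 log units; beyond the scatter), so among these four compounds the two groups with hetero atoms in the ring give measured numbers, the two phenyl groups stop at a limit, and no compound goes against this. A hetero atom in the ring does not fix the number on its own, however, since the two such rings still differ, with a 3.0-fold higher number from compound 1 to compound 4 (0.48 log units; beyond the scatter).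

How far compound 2 and compound 3 lie from each other cannot be read, and their steps to the other compounds have no true size, for both stop at a limit of the test and not at a number: the limit of > 64 ug/mL in this assay, at which 2 of the 4 values shown sit. Going by these compounds, it also stays open whether the ring nitrogen or the sulfur of 1,2-thiazol-4-yl matters more, and whether a phenyl ring carrying an amine or a carboxylic acid in this place would give a number or stop at that limit.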